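This account rests on a few compounds, and the source may have more. Where it says the series, first, only, none or still open, it means among the compounds named here.

Measured so far:

- Compound 1 `Cc1ccc(OCC(=O)N(Cc2cccs2)c2cccnc2)cc1` — 198 nM
- Compound 2 `CCN(Cc1cccs1)C(=O)COc1ccc(F)cc1` — 422 nM
- Compound 3 `CCN(Cc1ccoc1)C(=O)COc1ccc(C)cc1` — 136 nM

All three were tested in an assay on HEK293 cells for agonist activity at transient receptor potential cation channel subfamily M member 8 (Homo sapiens), read by fluorescence and calcium flux, with a stated time of 15 min; on this read-out higher numbers stand for an effect only at larger amounts of compound and lower numbers for an effect already at smaller amounts. Compound 1 stands second highest of the three numbers. Its nearest neighbour is compound 3, whose number is lower but only by an amount that falls within the scatter of repeated measurements, so the two cannot be told apart. Compound 2 gives the highest number, and its gap to compound 1 lies beyond the scatter.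

Compound 4 `Cc1ccc(OCC(=O)N(Cc2cccs2)c2ncco2)cc1` has not yet been measured. It differs from compound 1 in one place: 1,3-oxazol-2-yl in place of pyridin-3-yl on an amide-type nitrogen. Both groups are flat aromatic rings, but the new one is smaller and carries one more hydrogen-bond acceptor.

Among the measured compounds shown here, no pair among the measured compounds shows the effect of swapping one ring on this nitrogen for another, so there is no measured step to lean on. The expectation is therefore a modest change only, of a size close to the scatter, with no firm direction. Compound 4 is expected to give about 250 nM, with a likely range from 80 nM to 800 nM. This estimate corresponds to an expected step of a 1.3-fold higher number from compound 1 to compound 4 (0.10 log units; within the scatter).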

Compound 4, half-maximal effective concentration: 0.3 nM
For compound 4 the middle estimate is 830-fold (2.92 log units) above the measured one, and the stated range ends above it.
By their numbers in this assay, from the lowest: compound 4; then compounds 3 and 1 (each within the scatter of the next); then compound 2.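

In this assay, among the compounds shown here, the group on the amide-type nitrogen proves to be a highly sensitive point in the molecule, something the earlier compounds could not show because no two of them formed a pair differing only there. Replacing pyridin-3-yl with 1,3-oxazol-2-yl gives a 660-fold lower number from compound 1 to compound 4 (2.82 log units; beyond the scatter), so this one change, with the rest of the structure left the same, moves the number far beyond the scatter of repeated measurements. The swap alters several things at once, including ring size, the hetero atoms and the count of hydrogen-bond acceptors, and no measurement here separates these differences or explains the size of the step.

The compounds shown leave open whether this large step is specific to 1,3-oxazol-2-yl or would also appear with a related ring such as 1,3-thiazol-2-yl or pyridin-2-yl. They also leave open whether the same swap would have a similar effect in a compound carrying fluoro in place of the methyl group on the core of compound 4.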